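A few compounds are considered here, and "the series" means these few. Any claim that something is new, unique, unknown or untested is made for them only; others in the source may bear on it.

Measured so far:
compound 1 `CC1=CC[C@H](C(C)(C)N=C=S)CC1` — in a functional assay on U-251 cells (Homo sapiens) for inhibition, read by sulforhodamine B assay, with a stated time of 48 h (on this read-out lower numbers stand for stronger inhibition of growth and higher numbers for weaker inhibition of growth), compound 1 gives > 100000 nM
compound 2 `COc1ccc(/C=N/NC(=S)NC(C)(C)[C@H]2CC=C(C)CC2)cc1` — in this assay compound 2 gives 71900 nM
compound 3 `CC1=CC[C@H](C(C)(C)NC(=S)N/N=C/c2cccc([N+](=O)[O-])c2)CC1` — in this assay compound 3 gives > 100000 nM

Within the data shown here, compound 2 stands as the only compound of the three with an actual number in this assay. The result for compound 1 is a limit of the assay, not a number. The result for compound 3 is likewise a limit. Two of the three entries thus sit at the limit of > 100000 nM in this assay, at which 2 of the 3 values shown sit, and compound 2 alone gives a reading below it, though still a weak one.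

Compound 4 `CC1=CC[C@H](C(C)(C)NC(=S)N/N=C/c2ccc[nH]2)CC1` differs from compound 2 in one place: 1H-pyrrol-2-yl in place of 4-methoxyphenyl on a carbon with a double bond to nitrogen, that is, 1H-pyrrol-2-yl in place of 4-methoxyphenyl on the carbon carrying the double bond to nitrogen. Among the measured compounds shown here, no step between measured compounds covers a change of this kind, so there is nothing to set a direction. The expected step from compound 2 to compound 4 is none beyond the scatter, a 1.1-fold higher number from compound 2 to compound 4 (0.05 log units; within the scatter). Compound 4 is therefore estimated at 80000 nM, with an expected range from 30000 nM to 200000 nM, and a real chance that only a limit is reported.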

Compound 4, concentration for total growth inhibition: 3900 nM
Compound 4: middle estimate off by 21-fold (1.31 log units), on the high side, and the stated range ends above it.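

In this assay, the group on the carbon with a double bond to nitrogen can move the read-out well beyond the scatter: 1H-pyrrol-2-yl in place of 4-methoxyphenyl gives an 18-fold lower number from compound 2 to compound 4 (1.27 log units; beyond the scatter). Among these compounds, the earlier compounds offered no step at this place, so this is the first sign that a change here can matter, and that a five-membered aromatic ring with 1 hetero atom is tolerated. Nothing available accounts for the size of this step.

The compounds shown do not separate the effect of the five-membered ring from that of the hydrogen on the ring nitrogen, which furan-2-yl or 1-methyl-1H-pyrrol-2-yl in the same place would address. They also leave open whether a six-membered ring with a ring nitrogen, such as pyridin-2-yl, would give a similar number.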